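Methoxy in place of bromo in a cytotoxic series

The source may hold more compounds than are shown below. What is called first, only, known or untested is meant among the compounds shown, and "the series" means these compounds.

Measured in a functional assay on SK-OV-3 cells (Homo sapiens) for cytotoxicity; a higher number here means a weaker inhibitor of growth, a lower number a stronger inhibitor of growth:
compound 1 `COc1ccc(C2=C(c3ccc(SC)cc3)CC3CCCN3C2=O)cc1O` gives > 100000 nM (a limit)
compound 2 `COc1ccc(C2=C(c3ccc(SC)cc3)CC3CCCN3C2=O)cc1Br` gives 3000 nM
compound 3 `CSc1ccc(C2=C(c3ccc(F)c(C)c3)C(=O)N3CCCC3C2)cc1` gives 300 nM

The value of compound 1 is a limit and not a number. Among the measured compounds shown here, of the two actual numbers, the one for compound 2 is the higher. The gap to the other is a 10-fold lower number from compound 2 to compound 3 (1.00 log units; beyond the scatter) for 4-fluoro-3-methylphenyl in place of 3-bromo-4-methoxyphenyl on a double-bonded ring carbon, a modest step.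

Compound 4 `COc1ccc(C2=C(c3ccc(SC)cc3)CC3CCCN3C2=O)cc1OC` has methoxy in place of bromo on an aromatic carbon and is otherwise the same as compound 2. The closest measured change is an at least 33-fold lower number from compound 1 to compound 2 (1.52 log units; beyond the scatter) for bromo in place of hydroxy on an aromatic carbon, a large step that starts from a limit. For the measured compounds named here, no measured step brings in this methoxy, so the size of the change remains uncertain. A modest step towards a higher number is expected, well short of the large one seen with hydroxy. The estimated change is a 2.7-fold higher number from compound 2 to compound 4 (0.43 log units; beyond the scatter) in this series. For compound 4 the estimated value is 8000 nM with an expected range from 2000 nM to 40000 nM in this series.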

Compound 4, concentration for 50% growth inhibition: 9000 nM
Compound 4: the middle estimate sits 1.1-fold (0.05 log units) below what was measured; measured number inside the range.
By their numbers in this assay, from the lowest: compound 3; then compound 2; then compound 4. At a limit, above all of these: compound 1.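

In this assay, the position ortho to a methoxy group now has a second non-hydroxy group, and methoxy in place of bromo is only a modest step: a 3.0-fold higher number from compound 2 to compound 4 (0.48 log units; beyond the scatter). Methyl in place of hydrogen on the oxygen gives an at least 11-fold lower number from compound 1 to compound 4 (1.04 log units; beyond the scatter), so an oxygen at this position is compatible with measurable growth inhibition once it no longer carries that hydrogen. The value of compound 1 is a limit and not a number: the limit of > 100000 nM in this assay, at which 1 of the 4 values shown sits.

Open, going by these compounds, is how an amine, a chlorine or a longer chain such as ethoxy would read at this position. Also open, on these data alone, is whether the order of bromo and methoxy holds when the other aryl group or the core changes.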